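Swapping the Sulfonyl Aryl Ring: Methoxy in Place of Halogens

The source may report more compounds than this note shows. Statements on the series, on what has been measured and on what is new or still open speak of the compounds shown alone.

Measured compounds and their read-outs in an assay on isolated protein for displacement of a labelled ligand from metabotropic glutamate receptor 5 (Homo sapiens), with a stated time of 60 min, tested at 1 uM; a lower number here means less inhibition, a higher number more inhibition at the concentration tested (going by the name of the read-out):
compound 1 `CC1CCN(c2c(S(=O)(=O)c3ccc(Cl)c(Cl)c3)cnc3cc(F)ccc23)CC1` gives 94%
compound 2 `COc1ccc(S(=O)(=O)c2cnc3cc(F)ccc3c2N2CCC(C)CC2)cc1OC` gives 83%
compound 3 `CC1CCN(c2c(S(=O)(=O)c3ccc(F)c(Cl)c3)cnc3cc(F)ccc23)CC1` gives 94%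

Compound 3 stands level with compound 1 at the top of these three numbers, the two being within the scatter of each other: no change at the digits printed from compound 1 to compound 3 (within the scatter). Compound 2 sits clearly lower, as the step of a number 11 percentage points higher from compound 2 to compound 3 (beyond the scatter) shows.

The unmeasured compound 4 `COc1ccc(S(=O)(=O)c2cnc3cc(F)ccc3c2N2CCC(C)CC2)cc1` differs from compound 3 in one place: 4-methoxyphenyl in place of 3-chloro-4-fluorophenyl on a sulfonyl sulfur. Among the compounds with values here, two measured steps bear on this change, since both trade a halogenated ring on the sulfonyl sulfur for a methoxy-bearing one: a number 11 percentage points lower from compound 1 to compound 2 (beyond the scatter) and a number 11 percentage points higher from compound 2 to compound 3 (beyond the scatter). Each was a modest step beyond the scatter, and in both the methoxy-bearing ring gave the lower number. Compound 4 carries one methoxy group rather than the two of compound 2, so the expected step of a number 9 percentage points lower from compound 3 to compound 4 (within the scatter) is a modest decrease, perhaps a little smaller than those two steps, though this rests on three compounds only. Compound 4 is therefore estimated at 85% in this assay, with a likely range from 72% to 94%.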

Compound 4, a percentage reported as inhibition, at one concentration (the size of the read-out at that concentration, not a potency): 90%
Compound 4: middle estimate off by 5 percentage points, on the low side, within the range that was stated.
By their numbers in this assay, from the lowest: compounds 2, 4, 1 and 3 (each within the scatter of the next, the first and the last beyond it).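

In this assay, putting 4-methoxyphenyl on the sulfonyl sulfur in place of a halogenated ring gives a number 4 percentage points lower from compound 3 to compound 4 (within the scatter) and a number 4 percentage points lower from compound 1 to compound 4 (within the scatter), so a methoxy-bearing ring at this position does not have to separate from the halogenated rings, something compound 2 alone could not reveal. Taking one methoxy group away from the ring of compound 2 gives a number 7 percentage points higher from compound 2 to compound 4 (within the scatter), so compound 4 cannot be told apart from compound 2 on one side or from compound 1 and compound 3 on the other, even though compound 2 stands beyond the scatter of those last two. No measurement on hand offers a reason for these numbers.

As far as these compounds go, whether the position would hold up with a longer chain such as butoxy in place of methoxy, or with an amine or a carboxylic acid on the ring, remains open. Each number is also a percentage at a single concentration rather than a potency, so compounds that look alike here could still differ when tested across a range of concentrations.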